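Working notes: a ring hydroxy on compound 1

The source may hold more compounds than are shown below. What is called first, only, known or untested is meant among the compounds shown, and "the series" means these compounds.

Compound 1 `CCCCCCCCc1ccc(C(=O)C[C@@H]2CCCN2)cc1` gives 2500 nM
Compound 2 `CCCCCCCCc1ccc(CC[C@@H]2CCCN2)cc1` gives 2800 nM
Compound 3 `CCCCCCCCc1ccc(C(C[C@@H]2CCCN2)OC)cc1` gives 3000 nM

All three values come from a functional assay on FL5.12 cells (Mus musculus) for cytotoxicity, read by flow cytometry and propidium iodide staining, with a stated time of 48 h (a lower number here means a stronger inhibitor, a higher number a weaker inhibitor), and lie within the usual scatter of one another, so compound 1 at 2500 nM stands level with the other two, and no order can be read among them.

Compound 4 `CCCCCCCCc1ccc(C(=O)C[C@@H]2C[C@@H](O)CN2)cc1` keeps the core of compound 1 and differs from it in one place: hydroxy in place of hydrogen on a saturated ring carbon. This is hydroxy in place of hydrogen on a saturated ring carbon, turning pyrrolidin-2-yl into 4-hydroxypyrrolidin-2-yl.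

For the measured compounds named here, the only measured single-place step is a 1.1-fold higher number from compound 2 to compound 3 (0.03 log units; within the scatter), which puts methoxy in place of hydrogen on a saturated chain carbon. It bears on the question only loosely, since both the group and the place differ. Going by the values given here, no measured compound carries a group on this ring, so the series offers no direct guide, and the range has to stay wide. No step beyond the scatter is expected, and no direction can be firmly assigned. The estimated step is a 1.2-fold higher number from compound 1 to compound 4 (0.08 log units; within the scatter) and it remains an expectation only. For compound 4 the expected value is 3000 nM, with an estimated range from 1300 nM to 7000 nM until the measurement is available.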

Compound 4, half-maximal inhibitory concentration: 2100 nM
The estimate for compound 4 lay 1.4-fold (0.15 log units) above the measured number, within the range that was stated.
By their numbers in this assay, from the lowest: compounds 4, 1, 2 and 3 (each within the scatter of the next).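

In this assay the change from pyrrolidin-2-yl to 4-hydroxypyrrolidin-2-yl gives a 1.2-fold lower number from compound 1 to compound 4 (0.08 log units; within the scatter) and so leaves compound 4 level with compound 1. Compounds 1 to 3 differ only on the chain and carry no group on this ring, so they could not show that a saturated ring carbon, two ring bonds from the ring nitrogen, takes a hydroxy, with its hydrogen-bond donor and acceptor, without a step beyond the scatter. No measurement at hand bears on why the two compounds stand level.

On these data alone, whether a larger or differently charged group on the same ring carbon, such as methoxy, an amine or a carboxylic acid, would also stay level with compound 1 remains open. Also open, as far as these compounds go, is whether hydroxy on this ring gives a similar step when the rest of the molecule changes, as with the saturated chain of compound 2 or an octyl chain replaced by a longer chain.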